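Swapping the amine headgroup on a flavone side chain

The compounds below may be only part of what the source reports. "The series", "measured", "known", "first", "only" and "open" are said of these compounds alone.

Three compounds share a core and differ only in the amine that ends the chain. Compound 1 `COc1cc2oc(-c3ccccc3)cc(=O)c2c(O)c1OCCCN1CCN(C)CC1` gives 31300 nM in a functional assay on BCG823 cells (Homo sapiens) for antiproliferative activity, read by MTT assay, with a stated time of 48 h; a higher number here means a weaker inhibitor, a lower number a stronger inhibitor. Compound 2 `COc1cc2oc(-c3ccccc3)cc(=O)c2c(O)c1OCCCCN1CCCC1` gives 10600 nM, and compound 3 `COc1cc2oc(-c3ccccc3)cc(=O)c2c(O)c1OCCCN1CCCC1` gives 6500 nM. Compound 3 has the lowest number of the three; its nearest neighbour is compound 2, within the scatter, while compound 1 lies furthest away, beyond it. The two steps away from compound 1 are a 3.0-fold lower number from compound 1 to compound 2 (0.47 log units; beyond the scatter) and a 4.8-fold lower number from compound 1 to compound 3 (0.68 log units; beyond the scatter), both modest; between the two pyrrolidine-bearing compounds the step is a 1.6-fold lower number from compound 2 to compound 3 (0.21 log units; within the scatter), which is within the scatter.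

Compound 4 `CCN(CC)CCCOc1c(OC)cc2oc(-c3ccccc3)cc(=O)c2c1O` is the next step from compound 3. The change is diethylamino in place of pyrrolidin-1-yl on a saturated chain carbon, three bonds along the chain from an oxygen on an aromatic ring. Among the compounds with values here, no measured step exchanges pyrrolidin-1-yl for an open-chain amine, so the closest guides are the modest steps from compound 1 and the flat step from compound 2 to compound 3. A head-group change of this kind is therefore expected to move this assay little, if at all, beyond the scatter. For compound 4 the estimated value is 7000 nM, within a range of 2500 nM to 20000 nM. This estimate corresponds to an expected step of a 1.1-fold higher number from compound 3 to compound 4 (0.03 log units; within the scatter).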

Compound 4, half-maximal inhibitory concentration: 5700 nM
Estimate against measurement, compound 4: 1.2-fold (0.09 log units) above; the measured number falls inside the stated range.
By their numbers in this assay, from the lowest: compounds 4, 3 and 2 (each within the scatter of the next); then compound 1.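

The ring of the pyrrolidin-1-yl group is not needed at this place on the saturated chain: in this assay, a 1.1-fold lower number from compound 3 to compound 4 (0.06 log units; within the scatter) follows from replacing it with the open-chain diethylamino group, which has the same count of heavy atoms and hydrogen-bond acceptors. Compound 4 also stays close to the compound carrying the (pyrrolidin-1-yl)methyl group, with a 1.9-fold lower number from compound 2 to compound 4 (0.27 log units; within the scatter) in the same assay, whereas a 5.5-fold lower number from compound 1 to compound 4 (0.74 log units; beyond the scatter) confirms that compound 1, with its 4-methylpiperazin-1-yl group, remains the one clearly set apart at the high end of the series. No measurement shown here accounts for why these two amines read alike or why the 4-methylpiperazin-1-yl group stands apart.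

The compounds shown leave open whether smaller or differently shaped amines, such as dimethylamino or piperidin-1-yl, would fall with compounds 2, 3 and 4. They also leave open whether morpholin-4-yl, which carries a ring oxygen in place of the second ring nitrogen of the 4-methylpiperazin-1-yl group, would read like compound 1 or like the others.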